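This account rests on a few compounds, and the source may have more. Where it says the series, first, only, none or still open, it means among the compounds named here.

Measured so far in a functional assay on MKN-45 cells (Homo sapiens) for antiproliferative activity, read by MTT assay, with a stated time of 72 h, tested at 10 uM; on this read-out higher numbers stand for more inhibition at the one concentration tested (going by the name of the read-out) and lower numbers for less inhibition:
compound 1 `CC(O)C(=O)Nc1cc(Oc2ccc(Nc3nccc4[nH]cc(-c5ccc(F)cc5)c(=O)c34)cc2F)ccn1`: 67.3%
compound 2 `CC(C)C(=O)Nc1cc(Oc2ccc(Nc3nccc4[nH]cc(-c5ccc(F)cc5)c(=O)c34)cc2F)ccn1`: 95.4%
compound 3 `CC(C)(O)Cn1cc(-c2ccc(F)cc2)c(=O)c2c(Nc3ccc(Oc4ccnc(NC(=O)C5CC5)c4)c(F)c3)nccc21`: 44.3%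

Compound 2 stands highest of the three numbers in this assay; compound 1 sits beyond the scatter below it, and compound 3 sits furthest below it. Compound 4 `O=C(CO)Nc1cc(Oc2ccc(Nc3nccc4[nH]cc(-c5ccc(F)cc5)c(=O)c34)cc2F)ccn1` is not yet measured. It differs from compound 2 in one place: hydroxymethyl in place of isopropyl on a carbonyl carbon. Among the measured compounds shown here, one measured step bears on this. Going from compound 1 to compound 2 swapped a hydroxy for a methyl on the chain carbon bound to the carbonyl and gave a number 28.1 percentage points higher from compound 1 to compound 2 (beyond the scatter). Compound 4 brings a hydroxy back, with a shorter chain, so a drop beyond the scatter is expected, estimated as a number 35.4 percentage points lower from compound 2 to compound 4 (beyond the scatter) in this assay. Compound 4 is therefore expected to give about 60%, within 38% to 82%.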

Compound 4, a percentage reported as inhibition, at one concentration (the size of the read-out at that concentration, not a potency): 63%
Estimate against measurement, compound 4: 3 percentage points below, within the range that was stated.
By their numbers in this assay, from the lowest: compound 3; then compounds 4 and 1 (each within the scatter of the next); then compound 2.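

In this assay hydroxymethyl in place of isopropyl on the carbonyl carbon gave a number 32.4 percentage points lower from compound 2 to compound 4 (beyond the scatter) and so a second hydroxy-bearing group falls short of isopropyl. Hydrogen in place of methyl on the hydroxy-bearing carbon gave a number 4.3 percentage points lower from compound 1 to compound 4 (within the scatter) and so the presence of that methyl cannot be told apart on this read-out. Nothing measured here gives a reason for these numbers. The compounds shown leave open how an amine or a methoxymethyl group would read on the same carbonyl carbon, and whether a longer chain would match isopropyl.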